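The compounds below may be only part of what the source reports. "The series", "measured", "known", "first", "only" and "open" are said of these compounds alone.

Compound 1 `COc1cc(C(=O)c2sc(-c3ccc(Br)cc3)cc2N)cc(OC)c1OC` and compound 2 `COc1cc(C(=O)c2sc(-c3cccc([N+](=O)[O-])c3)cc2N)cc(OC)c1OC` share a core and differ only in the aryl group carried on it. In a functional assay on CCRF-CEM cells (Homo sapiens) for antiproliferative activity (on this read-out lower numbers stand for stronger inhibition and higher numbers for weaker inhibition), compound 1 gives 86 nM, while compound 2 gives 5.9 nM; the change a 15-fold lower number from compound 1 to compound 2 (1.16 log units; beyond the scatter) came with 3-nitrophenyl in place of 4-bromophenyl on an aromatic carbon. Compound 2 thus stands at the lowest of the two numbers, with compound 1 as its nearest neighbour at a higher value. Compound 3 `COc1cc(C(=O)c2sc(-c3ccsc3)cc2N)cc(OC)c1OC` is not yet measured; it differs from compound 2 by thiophen-3-yl in place of 3-nitrophenyl on an aromatic carbon. Within the data shown here, the only step on record, from compound 1 to compound 2, concerns the same position but neither of its groups, so it shows that this position tolerates large swings without pointing to a direction for thiophen-3-yl. Between those two values, compound 3 is therefore expected to land at an estimated 30 nM (range 5 nM to 200 nM), meaning an expected step of a 5.1-fold higher number from compound 2 to compound 3 (0.71 log units; beyond the scatter) in this assay.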

Compound 3, half-maximal inhibitory concentration: 9.6 nM
Compound 3: the middle estimate sits 3.1-fold (0.49 log units) above what was measured, within the range that was stated.
By their numbers in this assay, from the lowest: compounds 2 and 3 (each within the scatter of the next); then compound 1.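

In this assay, thiophen-3-yl in place of 3-nitrophenyl gives a 1.6-fold higher number from compound 2 to compound 3 (0.21 log units; within the scatter), so in this pair neither the nitro group nor a six-membered aromatic ring of carbon only is needed at this position for a number of this order. The same group in place of 4-bromophenyl gives a 9.0-fold lower number from compound 1 to compound 3 (0.95 log units; beyond the scatter), which makes compound 1 the one that stands apart, and the low number of compound 2 no longer rests on a single group. Nothing given here explains these differences.

The compounds shown leave open whether the higher number of compound 1 follows from the bromine itself or from where it sits on the phenyl ring, as a 3-bromophenyl or a 4-nitrophenyl group would tell. Going by these compounds, how an unsubstituted phenyl ring, thiophen-2-yl, an amine or a carboxylic acid would fare at this position also remains open.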